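This account rests on a few compounds, and the source may have more. Where it says the series, first, only, none or still open, it means among the compounds named here.

Compound 1 `CC(C)=CCC/C(C)=C/CC1Cc2c(O)cc(=O)n(CCCO)c2CC1(C)C` carries a free hydroxyl on its core, and compound 2 `COc1ccc(NC(=O)Oc2cc(=O)n(CCCO)c3c2CC(C/C=C(\C)CCC=C(C)C)C(C)(C)C3)cc1` is the same core with that hydroxyl turned into a carbamate. In a functional assay on PANC-1 cells (Homo sapiens) for inhibition, read by MTT assay, with a stated time of 24 h, tested at 10 uM (a lower number here means less inhibition, a higher number more inhibition at the concentration tested (going by the name of the read-out)), compound 1 gives 0%, and compound 2 gives 0%. The single measured step, no change at the digits printed from compound 1 to compound 2 (within the scatter), came with (4-methoxyphenyl)carbamoyl in place of hydrogen on an oxygen on an aromatic ring, so compound 2 stands level with compound 1 at the digits shown. Compound 3 `COc1ccccc1NC(=O)Oc1cc(=O)n(CCCO)c2c1CC(C/C=C(\C)CCC=C(C)C)C(C)(C)C2` is not yet measured in this assay. Its difference from compound 2 is 2-methoxyphenyl in place of 4-methoxyphenyl on an amide-type nitrogen; the two compounds have the same atoms, joined differently. Among the compounds with values here, the only step on record was flat, and nothing here separates the two methoxyphenyl groups, so the step from compound 2 to compound 3 is expected to be a number 2 percentage points higher from compound 2 to compound 3 (within the scatter), none beyond the scatter. Compound 3 is therefore estimated at 2%, with a range from 0% to 12%.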

Compound 3, a percentage reported as inhibition, at one concentration (the size of the read-out at that concentration, not a potency): 0%
Beside the measured number, compound 3's estimate is 2 percentage points above it; the measured number falls inside the stated range.
By their numbers in this assay, from the lowest: compounds 1, 2 and 3 (each within the scatter of the next).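

In this assay, 2-methoxyphenyl in place of 4-methoxyphenyl on the amide-type nitrogen brings no change at the digits printed from compound 2 to compound 3 (within the scatter), so these two groups cannot be told apart here. Setting the new carbamate against the free hydroxyl gives no change at the digits printed from compound 1 to compound 3 (within the scatter), which means that neither of the two methoxyphenyl carbamates departs from the hydroxyl compound in this read-out. No available evidence bears on this flat result.

With all three compounds reading the same, the data do not show whether any change at this oxygen can raise the inhibition. Still open, on these data alone, is what a carbamate would do if its phenyl ring carried a carboxylic acid or an amine instead of methoxy, or if a longer chain stood in place of the methoxyphenyl group.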